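This account rests on a few compounds, and the source may have more. Where it says the series, first, only, none or still open, it means among the compounds named here.

In a functional assay on BT-474 cells (Homo sapiens) for inhibition, read by fluorescence, with a stated time of 72 h (on this read-out higher numbers stand for weaker inhibition of growth and lower numbers for stronger inhibition of growth), compound 1 (`CC(C)CCn1cnc2c(Nc3ccc(Cl)cc3)nc(N[C@H]3CC[C@H](N)CC3)nc21`) gives 5100 nM and compound 2 (`CCCCn1cnc2c(NCc3cccc(Cl)c3)nc(N[C@H]3CC[C@H](N)CC3)nc21`) gives 4700 nM and the two lie within the scatter of each other, so compound 2 stands level with compound 1. Compound 3 (`CC(C)CCn1cnc2c(NCc3cccc(Cl)c3)nc(N[C@H]3CC[C@H](N)CC3)nc21`) differs from compound 2 by methyl in place of hydrogen on a saturated chain carbon bound to two saturated chain carbons through methyl in place of hydrogen on a saturated chain carbon bound to two saturated chain carbons, which reads butyl to isopentyl. Going by the values given here, no measured pair shows this change alone, so only a step within the scatter is expected in this assay for now. In this assay the estimated value for compound 3 is 4500 nM (expected range 2200 nM to 9000 nM).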

Compound 3, concentration for 50% growth inhibition: 6600 nM
Beside the measured number, compound 3's estimate is 1.5-fold (0.17 log units) below it; measured number inside the range.
By their numbers in this assay, from the lowest: compounds 2, 1 and 3 (each within the scatter of the next).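

In this assay, the chain change of butyl to isopentyl gives a 1.4-fold higher number from compound 2 to compound 3 (0.15 log units; within the scatter), so compounds 2 and 3 stand level. With isopentyl held, 3-chlorobenzyl in place of 4-chlorophenyl on a nitrogen on an aromatic ring gives a 1.3-fold higher number from compound 1 to compound 3 (0.11 log units; within the scatter), so neither single change separates these compounds on this read-out. No independent data bear on this result. From the compounds shown here alone, whether a longer chain, or a chain carrying an amine or a carboxylic acid, in place of isopentyl would separate from these compounds stays open.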